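Chloro in place of acetyl on the pendant aryl ring

This account rests on a few compounds, and the source may have more. Where it says the series, first, only, none or still open, it means among the compounds named here.

Compound 3 `CC(=O)c1ccc(-c2cn3ccnc3c(-c3ccc4ncn(C5CCCCC5)c4c3)n2)cc1` stands second of the three compounds measured in a functional assay on T47D cells (Homo sapiens) for inhibition, read by sulforhodamine B assay, with a stated time of 48 h, tested at 10 uM (on this read-out higher numbers stand for more inhibition at the one concentration tested (going by the name of the read-out) and lower numbers for less inhibition), where compound 3 gives 54.4%. Above it compound 1 `O=Cc1ccc(-c2cn3ccnc3c(-c3ccc4ncn(C5CCCCC5)c4c3)n2)cc1` gives 98%; below it compound 2 `Fc1ccc(-c2cn3ccnc3c(-c3ccc4ncn(C5CCCCC5)c4c3)n2)cc1` gives 33.3%. Compound 4 `Clc1ccc(-c2cn3ccnc3c(-c3ccc4ncn(C5CCCCC5)c4c3)n2)cc1` differs from compound 3 by chloro in place of acetyl on an aromatic carbon, 4-acetylphenyl becoming 4-chlorophenyl. Going by the values given here, two measured steps bear on this change: a number 64.7 percentage points lower from compound 1 to compound 2 (beyond the scatter) and a number 21.1 percentage points higher from compound 2 to compound 3 (beyond the scatter). In both, the halogen-bearing compound 2 lies well under the carbonyl-bearing compounds, so a step down beyond the scatter is expected, estimated as a number 19.4 percentage points lower from compound 3 to compound 4 (beyond the scatter). Landing near the fluoro analogue, compound 4 is accordingly expected at 35% within a range of 15% to 55%. Among the compounds with values here, no measured step exchanges acetyl for chloro directly, so the size of the drop remains uncertain.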

Compound 4, a percentage reported as inhibition, at one concentration (the size of the read-out at that concentration, not a potency): 27.6%
Compound 4: the middle estimate sits 7.4 percentage points above what was measured; the measured number falls inside the stated range.
By their numbers in this assay, from the lowest: compounds 4 and 2 (each within the scatter of the next); then compound 3; then compound 1.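

In this assay, swapping one halogen for the other on this aromatic carbon, para to a large group, separates nothing (a number 5.7 percentage points lower from compound 2 to compound 4 (within the scatter)). Chloro, like fluoro, lies well under both carbonyl-bearing groups (a number 26.8 percentage points lower from compound 3 to compound 4 (beyond the scatter); a number 70.4 percentage points lower from compound 1 to compound 4 (beyond the scatter)), so among these four compounds the gap between halogens and carbonyl groups holds for a second halogen, with no exception. Nothing measured here gives a reason for that gap.

Still open, from the compounds shown here alone, is how an amine or a carboxylic acid would read in this place. A methyl ester or a longer ketone chain would show whether the read-out keeps falling from formyl through acetyl.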